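The source may report more compounds than this note shows. Statements on the series, on what has been measured and on what is new or still open speak of the compounds shown alone.

Of the compounds shown here, three have been measured. In an assay on CHO cells for displacement of a labelled ligand from adenosine receptor A3 (Homo sapiens), read by scintillation counting, with a stated time of 120 min, tested at 1 uM (on this read-out lower numbers stand for less inhibition and higher numbers for more inhibition at the one concentration tested (going by the name of the read-out)), compound 1 `N#Cc1c(N)nc(SCc2nc3ccccc3[nH]2)c(C#N)c1-c1ccc(OCC2CC2)cc1` gives 1%. Compound 2 `C=C(C)COc1ccc(-c2c(C#N)c(N)nc(SCC(N)=O)c2C#N)cc1` gives 4% in this assay, and compound 3 `N#Cc1c(N)nc(SCC(N)=O)c(C#N)c1-c1ccc(OCC2CCC2)cc1` gives 1% in this assay. Among the compounds with values here, the only single-point step measured so far, a number 3 percentage points lower from compound 2 to compound 3 (within the scatter), concerns the group on a saturated chain carbon bound to an oxygen on an aromatic ring and lies within the scatter. Compound 1 stands level with compound 3 at the digits shown; its value is within the scatter of compound 2 as well, so all three sit together at the low end of the read-out.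

Compound 4 `COC(=O)CSc1nc(N)c(C#N)c(-c2ccc(OCC3CC3)cc2)c1C#N` differs from compound 1 at the sulfur side of the core: methoxycarbonyl in place of 1H-benzimidazol-2-yl on a saturated chain carbon bound to a sulfur. Within the data shown here, no measured step touches this position, so nothing among the measured compounds speaks for a shift in this assay beyond the scatter. The step of a number 1 percentage points higher from compound 1 to compound 4 (within the scatter) is therefore expected to stay within the scatter. Compound 4 is expected to give about 2% in this assay, with a range from -8% to 14%.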

Compound 4, a percentage reported as inhibition, at one concentration (the size of the read-out at that concentration, not a potency): 1%
Compound 4: middle estimate off by 1 percentage points, on the high side, within the range that was stated.
By their numbers in this assay, from the lowest: compounds 1, 3, 4 and 2 (each within the scatter of the next).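

In this assay, within the data shown here, the step at the sulfur side of the core, no change at the digits printed from compound 1 to compound 4 (within the scatter), is the first reading at this position, and it lies within the scatter. The exchange is large in the counted terms: the leaving 1H-benzimidazol-2-yl has two aromatic rings and a hydrogen-bond donor, the entering methoxycarbonyl has no ring and no donor, yet this one pair shows no shift beyond the scatter. Nothing measured on these compounds speaks to why the read-out holds here.

With this pair at the low end of the read-out, it cannot show whether any group at this position would bring measurable inhibition at the one concentration tested. On these data alone, a carboxylic acid, an amine or a longer chain on a saturated chain carbon bound to a sulfur remains open.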